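Anilino versus cyclohexylamino on the shared core

The source may hold more compounds than are shown below. What is called first, only, known or untested is meant among the compounds shown, and "the series" means these compounds.

Measured compounds:
compound 1 `O=C1C(Nc2ccc(I)cc2)=CC(=O)c2c1nc1n2[C@H]2OC[C@@H](O)[C@H]2OC1`: 2530 nM
compound 2 `O=C1C(Nc2ccc(Br)cc2)=CC(=O)c2c1nc1n2[C@H]2OC[C@@H](O)[C@H]2OC1`: 1980 nM
compound 3 `O=C1C=C(NC2CCCCC2)C(=O)c2c1nc1n2[C@H]2OC[C@@H](O)[C@H]2OC1`: > 16000 nM

In a functional assay on ECa-109 cells for inhibition, with ECa-109 cell line (Homo sapiens) as the target, read by sulforhodamine B assay (a lower number here means a stronger inhibitor, a higher number a weaker inhibitor), compound 1 gives 2530 nM and compound 2 gives 1980 nM. Among the measured compounds shown here, the step of a 1.3-fold lower number from compound 1 to compound 2 (0.11 log units; within the scatter) is the only measured step in the set, and it alters a halogen on the aryl ring rather than the group on the amine nitrogen, so it speaks to the present change only indirectly. Compound 3 returns only a limit in this assay, > 16000 nM. Compound 3 therefore stands at the limit of > 16000 nM in this assay, at which 1 of the 3 values shown sits. Both anilino compounds, compound 1 and compound 2, give numbers inside the measured range, whereas the cyclohexylamino compound does not.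

Compound 4 `COc1cccc(NC2=CC(=O)c3nc4n(c3C2=O)[C@H]2OC[C@@H](O)[C@H]2OC4)c1` differs from compound 3 as follows: 3-methoxyphenyl in place of cyclohexyl on an amine nitrogen. Since the change returns the amine substituent to an aryl group of the kind carried by compound 1 and compound 2, compound 4 is expected to give a number again rather than a limit, an expected step of an at least 4.5-fold lower number from compound 3 to compound 4 (0.66 log units; beyond the scatter). Compound 4 is estimated at 3500 nM, within 1000 nM to 14000 nM; a limit remains possible.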

Compound 4, half-maximal inhibitory concentration: 7620 nM
Compound 4: the middle estimate sits 2.2-fold (0.34 log units) below what was measured, within the range that was stated.
By their numbers in this assay, from the lowest: compounds 2 and 1 (each within the scatter of the next); then compound 4. At a limit, above all of these: compound 3.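

In this assay, among the compounds shown here, 3-methoxyphenyl in place of cyclohexyl on the amine nitrogen gives an at least 2.0-fold lower number from compound 3 to compound 4 (0.32 log units; beyond the scatter), the first read on a change of the group at this position; the halogen step between compound 1 and compound 2 could not show this. The step is only a lower bound, since compound 3 stands at a limit of the assay and not at a number: the limit of > 16000 nM in this assay, at which 1 of the 4 values shown sits. Compound 4 differs from compound 1 and compound 2 in more than one place, so its value is not set against theirs.

Open, from the compounds shown here alone, is whether the aromatic ring alone accounts for the step or the methoxy group contributes to it. An unsubstituted phenyl on the same amine nitrogen of the core of compound 4 would separate the two.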